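Permeability across a shared core: compound 2 toward compound 3

The compounds below may be only part of what the source reports. "The series", "measured", "known", "first", "only" and "open" are said of these compounds alone.

Measured so far:
compound 1 `O=C(Nc1ccccc1)c1cccc(Oc2ccc3c(c2)c(=O)ncn3Cc2c(F)cc(F)cc2F)c1C(F)(F)F` gives 0.84 10^-6 cm/s
compound 2 `O=c1ncn(Cc2c(F)cc(F)cc2F)c2ccc(Oc3cccc(-c4nc5ncccc5o4)c3C(F)(F)F)cc12` gives 3 10^-6 cm/s

Of the compounds shown here, two built on the same core have been measured in an ADME assay on Caco-2 cells (Homo sapiens) for permeability, in the apical to basolateral direction; a lower number here means that the compound crosses the layer more slowly, a higher number that the compound crosses the layer faster. Compound 1 `O=C(Nc1ccccc1)c1cccc(Oc2ccc3c(c2)c(=O)ncn3Cc2c(F)cc(F)cc2F)c1C(F)(F)F` gives 0.84 10^-6 cm/s. Compound 2 `O=c1ncn(Cc2c(F)cc(F)cc2F)c2ccc(Oc3cccc(-c4nc5ncccc5o4)c3C(F)(F)F)cc12` gives 3 10^-6 cm/s, the higher of the two numbers. Going by the values given here, the only measured step is a 3.6-fold higher number from compound 1 to compound 2 (0.55 log units; beyond the scatter), a modest rise.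

Compound 3 `O=c1ncn(Cc2c(F)cc(F)cc2F)c2ccc(Oc3cccc(-c4ccc5[nH]ccc5c4)c3C(F)(F)F)cc12` has not yet been measured. Compared with compound 2 it carries a group of 9 heavy atoms (8 carbon, 1 nitrogen; one five-membered aromatic ring with 1 hetero atom, one six-membered aromatic ring of carbon only) in place of a group of 9 heavy atoms (6 carbon, 2 nitrogen, 1 oxygen; one five-membered aromatic ring with 2 hetero atoms, one six-membered aromatic ring with 1 hetero atom), on an aromatic carbon, on an aromatic carbon of a six-membered aromatic ring of carbon only, ortho to a trifluoromethyl group and meta to a large group; the group that enters is 1H-indol-5-yl, which brings one hydrogen-bond donor and no hydrogen-bond acceptor where the leaving group had none and three.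

Among the compounds with values here, no measured step describes this exchange directly. Within the data shown here, the single step from compound 1 to compound 2 shows that swapping a group of this size at this position can move the number beyond the scatter, but it does not say in which direction an indole would move it. For compound 3 the expected step is therefore a 1.2-fold lower number from compound 2 to compound 3 (0.08 log units; within the scatter), a small change that may well lie within the scatter. Compound 3 is estimated at 2.5 10^-6 cm/s, with a range of 1 10^-6 cm/s to 6 10^-6 cm/s.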

Compound 3, apparent permeability: 10.5 10^-6 cm/s
Beside the measured number, compound 3's estimate is 4.2-fold (0.62 log units) below it, and the stated range ends below it.
By their numbers in this assay, from the lowest: compound 1; then compound 2; then compound 3.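

In this assay, 1H-indol-5-yl in place of the two-ring group of compound 2, on the aromatic carbon ortho to a trifluoromethyl group, gives a 3.5-fold higher number from compound 2 to compound 3 (0.54 log units; beyond the scatter), so this position responds beyond the scatter even when the entering and leaving groups have the same heavy-atom count. Set against the phenylcarbamoyl group of compound 1, the same 1H-indol-5-yl gives a 13-fold higher number from compound 1 to compound 3 (1.10 log units; beyond the scatter), the only step among these compounds printed as large, which shows that the choice of group at this one aromatic carbon can span a wide range of the read-out while the rest of the molecule stays the same. No measurement shown here explains why the number rises with this exchange.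

The compounds leave open which part of the exchange carries the step, since the ring atoms and the counts of hydrogen-bond donors and acceptors all change together between compound 2 and compound 3. They also leave open where a naphthyl group, a benzofuranyl group or a simple amine on the same aromatic carbon would fall among the three numbers in this assay.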